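Ester chain length and cytotoxicity in the series

A few compounds are considered here, and "the series" means these few. Any claim that something is new, unique, unknown or untested is made for them only; others in the source may bear on it.

Of the compounds shown here, two have been measured so far. Compound 1 `CCCCCCCCCCCOC(=O)CCC(=O)N1CCN(CCCOc2cc3c(Nc4ccc(F)c(Cl)c4)ncnc3cc2OC)CC1` gives 2.8% in a functional assay on A549 cells (Homo sapiens) for cytotoxicity, read by MTT assay, with a stated time of 24 h, tested at 80 uM; a lower number here means a stronger effect, a higher number a weaker effect of the compound at the concentration tested. Compound 2 `CCCCCCCCCCCCCCCOC(=O)CCC(=O)N1CCN(CCCOc2cc3c(Nc4ccc(F)c(Cl)c4)ncnc3cc2OC)CC1` gives 81.1% in this assay, the higher of the two numbers and therefore the weaker effect at the concentration tested. Among the measured compounds shown here, the single measured step between them, a number 78.3 percentage points higher from compound 1 to compound 2 (beyond the scatter), is the only step available to date.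

Compound 3 `CCCCCCCCCCCCCCCCOC(=O)CCC(=O)N1CCN(CCCOc2cc3c(Nc4ccc(F)c(Cl)c4)ncnc3cc2OC)CC1` differs from compound 2 by one change: methyl in place of hydrogen on a saturated chain carbon, ten or more bonds along the chain from an oxygen next to a carbonyl group. The measured step that bears on this change is a number 78.3 percentage points higher from compound 1 to compound 2 (beyond the scatter), which runs in the same sense, growth of the same chain at the same place, but by a larger group. A single methyl at that place is expected to move the read-out in this assay in the same direction, by a smaller amount, and the read-out of compound 2 already leaves little room above it. The expected step is a number 4.9 percentage points higher from compound 2 to compound 3 (within the scatter). Compound 3 is therefore estimated at 86%, within a range of 68% to 100%.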

Compound 3, a percentage reported as activity, at one concentration (the size of the read-out at that concentration, not a potency): 74.3%
Compound 3: middle estimate off by 11.7 percentage points, on the high side; the measured number falls inside the stated range.
By their numbers in this assay, from the lowest: compound 1; then compounds 3 and 2 (each within the scatter of the next).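

In this assay, among the compounds shown here, the step of a number 6.8 percentage points lower from compound 2 to compound 3 (within the scatter) shows that methyl in place of hydrogen on a saturated chain carbon, ten or more bonds along the chain from an oxygen next to a carbonyl group, does not move the read-out beyond the scatter at this chain length, which the single large step of the earlier pair could not show. The wider change, pentyl in place of hydrogen at the same place, gives a number 71.5 percentage points higher from compound 1 to compound 3 (beyond the scatter) and is large, so among the three compounds the large difference separates compound 1 from compounds 2 and 3, while compounds 2 and 3 do not separate from each other. No measurement in hand bears on the origin of this difference.

Going by these compounds, the point along the chain at which the read-out changes remains open, since methyl, ethyl or propyl in place of hydrogen on the chain end of compound 1 would fall in the wide gap between compound 1 and compound 2. Also open, on these data alone, is whether a longer chain stays level with compounds 2 and 3, and whether a chain ending in an amine or a carboxylic acid follows the same course.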